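A Larger Group at the Position Where Methyl Hurt

The source may hold more compounds than are shown below. What is called first, only, known or untested is meant among the compounds shown, and "the series" means these compounds.

Of the compounds shown here, three have been measured in a functional assay on the whole organism (strain Wistar) for inhibition, with Rattus norvegicus as the target, read by paw edema, with stated times of 1 h and 3 h, at a dose of 70 mg/kg by the oral route; a higher number here means more inhibition at the dose given (going by the name of the read-out), a lower number less inhibition. Compound 1 `Clc1ccc2nc(Nc3nnc(-c4ccccc4)o3)sc2c1` gives 78.8% in this assay, compound 2 `Clc1ccc2nc(Nc3nnc(-c4ccccc4Cl)o3)sc2c1` gives 53%, and compound 3 `Cc1ccccc1-c1nnc(Nc2nc3ccc(Cl)cc3s2)o1` gives 23.9%. Compound 3 stands lowest of the three: the steps of a number 54.9 percentage points lower from compound 1 to compound 3 (beyond the scatter) and a number 29.1 percentage points lower from compound 2 to compound 3 (beyond the scatter) both fall beyond the scatter, so each group placed on that ring carbon so far has cost inhibition. Compound 4 `COC(=O)c1ccccc1-c1nnc(Nc2nc3ccc(Cl)cc3s2)o1` carries the change (methoxycarbonyl in place of methyl on an aromatic carbon). Going by the values given here, the steps that bear on it are a number 25.8 percentage points lower from compound 1 to compound 2 (beyond the scatter), where chloro at this carbon already lowered inhibition, and a number 29.1 percentage points lower from compound 2 to compound 3 (beyond the scatter), where methyl lowered it further. Methoxycarbonyl is larger than either group, and no measured change at this carbon has raised inhibition, so a small further drop or no step beyond the scatter is expected. For compound 4 an inhibition of 18% is estimated, within 5% to 35%, which means an expected step of a number 5.9 percentage points lower from compound 3 to compound 4 (within the scatter).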

Compound 4, a percentage reported as inhibition, in the whole organism at one dose (the size of the read-out at that dose, not a potency): 31%
Compound 4: middle estimate off by 13 percentage points, on the low side; low and high end bracket the measured number.
By their numbers in this assay, from the lowest: compounds 3 and 4 (each within the scatter of the next); then compound 2; then compound 1.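

In this assay, methoxycarbonyl brings four heavy atoms in place of the single one of methyl, yet the swap gives a number 7.1 percentage points higher from compound 3 to compound 4 (within the scatter) and so separates the two groups by no reliable margin; at this ring carbon, the larger group does not extend the earlier downward run. The position still carries a cost, with a number 22 percentage points lower from compound 2 to compound 4 (beyond the scatter) for the change from chloro and a number 47.8 percentage points lower from compound 1 to compound 4 (beyond the scatter) for the change from hydrogen, so chloro, methyl and methoxycarbonyl all fall short of plain hydrogen here. Nothing available explains why any of these groups lowers inhibition.

Going by these compounds, it remains open whether a group of another kind on this carbon, such as an amine or a carboxylic acid, could restore inhibition. It is also unknown whether methoxycarbonyl would give the same result on a different carbon of this ring.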